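A few compounds are considered here, and "the series" means these few. Any claim that something is new, unique, unknown or untested is made for them only; others in the source may bear on it.

Measured in a functional assay on KB cells (Homo sapiens) for cytotoxicity, read by MTT assay, with a stated time of 72 h; a higher number here means a weaker inhibitor, a lower number a stronger inhibitor:
- compound 1 `Cc1ccc(S(=O)(=O)c2nc3ccccc3nc2N2CCCC2)cc1` gives > 50000 nM, a limit of the assay
- compound 2 `O=S(=O)(c1ccc(Br)cc1)c1nc2ccccc2nc1N1CCCC1` gives > 50000 nM, a limit of the assay
- compound 3 `O=S(=O)(c1ccc(F)cc1)c1nc2ccccc2nc1N1CCCC1` gives 30100 nM

Compound 3 is the only one of these with an actual number. The other two compounds sit at the limit of > 50000 nM in this assay, at which 2 of the 3 values shown sit.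

In compound 4 `O=S(=O)(c1ccc(F)cc1)c1nc2ccccc2nc1N1CCC(O)CC1`, 4-hydroxypiperidin-1-yl replaces pyrrolidin-1-yl on an aromatic carbon, a change counted as 4-hydroxypiperidin-1-yl in place of pyrrolidin-1-yl on an aromatic carbon.

The measured steps, an at least 1.6-fold lower number from compound 1 to compound 3 (0.22 log units; that floor lies within the scatter) and an at least 1.6-fold lower number from compound 2 to compound 3 (0.22 log units; that floor lies within the scatter), swap a different group, so neither shows what this replacement does. The expectation therefore starts from compound 3 at 30100 nM, with no step beyond the scatter expected. The estimated step is a 1.2-fold higher number from compound 3 to compound 4 (0.07 log units; within the scatter).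

For compound 4 the expected value is 35000 nM, within an estimated range of 12000 nM to 90000 nM.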

Compound 4, half-maximal inhibitory concentration: 9580 nM
Beside the measured number, compound 4's estimate is 3.7-fold (0.56 log units) above it; measured number below the stated range.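

In this assay, the group on the aromatic carbon next to the ring nitrogen clearly matters: 4-hydroxypiperidin-1-yl in place of pyrrolidin-1-yl gives a 3.1-fold lower number from compound 3 to compound 4 (0.50 log units; beyond the scatter). The earlier comparisons swapped only methyl, bromo and fluoro, and none of them shows a step beyond the scatter, with two of those compounds giving no actual number: the limit of > 50000 nM in this assay, at which 2 of the 4 values shown sit.

Ring size and the hydroxyl change together here, so the compounds shown cannot say which one carries the step. Plain piperidin-1-yl or morpholin-4-yl at this place would separate the two, and whether the step holds with methyl or bromo instead of fluoro also stays open.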